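The compounds below may be only part of what the source reports. "The series", "measured", "known", "first", "only" and "open" are said of these compounds alone.

Of the compounds shown here, two so far have numbers in an assay on cells for inhibition of cytochrome P450 11B2, mitochondrial (Homo sapiens), read by HPLC, with a stated time of 90 min; on this read-out lower numbers stand for stronger inhibition and higher numbers for weaker inhibition. Compound 1 `Fc1ccc2nc(-c3ccnnc3)n(C3CC3)c2c1` gives 330 nM, while compound 2 `Cc1ncncc1-c1nc2cc(F)c(F)cc2n1C1CC1` gives 17 nM, the lower of the two and separated from compound 1 by a gap beyond the usual scatter. Compound 3 `Fc1cc2nc(-c3cncnc3C(F)F)n(C3CC3)c2cc1F` takes one step onward from compound 2: difluoromethyl in place of methyl on an aromatic carbon. Within the data shown here, no measured pair shows this change, so the expected step of a 1.5-fold higher number from compound 2 to compound 3 (0.17 log units; within the scatter) is taken as none beyond the scatter. Compound 3 is accordingly estimated at 25 nM, with a range from 8 nM to 80 nM.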

Compound 3, half-maximal inhibitory concentration: 18 nM
The estimate for compound 3 lay 1.4-fold (0.14 log units) above the measured number, within the range that was stated.
By their numbers in this assay, from the lowest: compounds 2 and 3 (each within the scatter of the next); then compound 1.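

Difluoromethyl in place of methyl on this aromatic carbon, next to the ring nitrogen, gives a 1.1-fold higher number from compound 2 to compound 3 (0.02 log units; within the scatter) in this assay. This is the first single change shown at this position, and it shows that the methyl can be exchanged for difluoromethyl with no shift beyond the scatter. No measurement here explains why the number stays put. From the compounds shown here alone, whether trifluoromethyl, an amine or an ethyl chain on the same carbon would also leave the number in place remains open. So does whether this exchange would behave the same way on another core.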